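The compounds below may be only part of what the source reports. "The series", "measured", "known", "first", "only" and "open" are said of these compounds alone.

Working notes on the series. The shared core is that of compound 1 `COC(=O)c1cc(-c2cccc(NC(=O)c3ccc(/C=C/C(=O)c4ccccc4O)cc3)c2)on1`; in an ADME assay on Vero cells (Chlorocebus sabaeus) for cytotoxicity, read by MTT assay, with a stated time of 72 h (a higher number here means that more compound is tolerated, a lower number that less compound is tolerated), compound 1 gives "not determined" (no result reported). Compound 2 `COC(=O)c1cc(-c2cccc(NC(=O)c3ccc(/C=C/C(=O)c4ccc(CC(C)C)cc4)cc3)c2)on1` carries a 4-isobutylphenyl on the carbonyl carbon whose other neighbour is a double-bonded chain carbon. In this assay compound 2 gives > 10 ug/mL, which is a limit of the assay and not a number. Where compound 2 stands is thus set only by the limit of > 10 ug/mL in this assay, at which 1 of the 2 values shown sits, and no single number in the set places it further. Compound 3 `COC(=O)c1cc(-c2cccc(NC(=O)c3ccc(/C=C/C(=O)c4cccc([N+](=O)[O-])c4)cc3)c2)on1` differs from compound 2 in one place: 3-nitrophenyl in place of 4-isobutylphenyl on a carbonyl carbon. For the measured compounds named here, no step between two measured compounds is at hand, so the size of this change has to be expected from the limit of compound 2 alone. The expected step that the limit leaves unreadable from compound 2 to compound 3 is small, within the scatter or near it, in no firm direction. For compound 3 the estimate in this assay is 15 ug/mL, expected to fall between 5 ug/mL and 50 ug/mL.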

Compound 3, half-maximal cytotoxic concentration: > 40 ug/mL
Compound 3: a limit, no number; the forecaster's own chance of this, stated with the estimate: 60%; middle value at least 2.6-fold (0.42 log units) away from the limit.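

For the compounds shown here, compound 2 and compound 3 both stand in this assay as limits of the assay, not numbers, so no step between them can be read. The compounds shown leave open whether 3-nitrophenyl in place of 4-isobutylphenyl shifts the tolerated concentration at all, and in which direction.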